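Sulfonamide series: hydroxyphenyl replacing chlorophenyl at the sulfonyl

A few compounds are considered here, and "the series" means these few. Any claim that something is new, unique, unknown or untested is made for them only; others in the source may bear on it.

Compound 1 `O=S(=O)(Nc1ccc(-c2nc3ccccc3o2)cc1)c1ccccc1Cl` is one of three sulfonamides examined so far in an assay on cells for inhibition of HSP60/HSP10 (Homo sapiens), with a stated time of 60 min; a higher number here means a weaker inhibitor, a lower number a stronger inhibitor. For compound 1 the result is only a limit of the assay, > 100000 nM. Compound 3 `O=S(=O)(Nc1ccc2oc(-c3ccccc3)nc2c1)c1ccc(Cl)cc1` likewise returns a limit in this assay, > 100000 nM. Among the compounds with values here, compound 2 `CS(=O)(=O)Nc1ccc(-c2nc3cc(NS(=O)(=O)c4ccc(Cl)s4)ccc3o2)cc1` is the only member with a number in this assay, 43000 nM. Two of the three values thus sit at the limit (the limit of > 100000 nM in this assay, at which 2 of the 3 values shown sit). Compound 4 `O=S(=O)(Nc1ccc(-c2nc3ccccc3o2)cc1)c1ccc(O)cc1` differs from compound 1 by 4-hydroxyphenyl in place of 2-chlorophenyl on a sulfonyl sulfur. Within the data shown here, no step between measured compounds covers this change, so the expectation rests on the weak series alone. The step this estimate implies, a number no higher from compound 1 to compound 4 (the limit leaves the size open), is expected to be at most a small shift toward stronger inhibition, within or near the scatter. Compound 4 is therefore estimated at 100000 nM in this assay, within 30000 nM to 300000 nM, with a fair chance that again only a limit is reported.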

Compound 4, half-maximal inhibitory concentration: 78000 nM
Compound 4: the middle estimate sits 1.3-fold (0.11 log units) above what was measured; measured number inside the range.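

Putting 4-hydroxyphenyl in place of 2-chlorophenyl on a sulfonyl sulfur gives in this assay an at least 1.2-fold lower number from compound 1 to compound 4 (0.10 log units; that floor lies within the scatter), the first step readable at this position. The core of compound 1 thus yields a measured number with this group, though the signal remains weak. The full size of the step cannot be read, because the value of compound 1 is a limit of the assay: the limit of > 100000 nM in this assay, at which 2 of the 4 values shown sit.

Going by these compounds, whether the hydroxy group or the loss of chlorine carries the step remains open. So does how 4-aminophenyl or 4-carboxyphenyl would read on this sulfonyl sulfur.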